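The compounds below may be only part of what the source reports. "The series", "measured", "known", "first", "only" and "open" are said of these compounds alone.

Compounds measured so far:

Compound 1: `CC(C)C[C@H](N)c1cc(C(F)(F)F)ccc1N1CCN(C(=O)COc2ccc(O)cc2)CC1` with 4600 nM in an assay on HEK293 cells for displacement of a labelled ligand from Melanocortin receptor 4 (Homo sapiens); on this read-out lower numbers stand for stronger inhibition and higher numbers for weaker inhibition.
Compound 2: `CC(C)C[C@H](N)c1cc(C(F)(F)F)ccc1N1CCN(C(=O)CCC2CCCCC2)CC1` with 5700 nM in this assay.
Compound 3: `CC(C)C[C@H](N)c1cc(C(F)(F)F)ccc1N1CCN(C(=O)COc2ccc3ccccc3c2)CC1` with 2000 nM in this assay.

Compound 1 gives the second highest of the three numbers. Its nearest neighbour is compound 2, with a 1.2-fold higher number from compound 1 to compound 2 (0.09 log units; within the scatter), a step within the scatter; its furthest is compound 3, with a 2.3-fold lower number from compound 1 to compound 3 (0.36 log units; beyond the scatter), a modest step beyond the scatter.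

Compound 4 is `CC(C)C[C@H](N)c1cc(C(F)(F)F)ccc1N1CCN(C(=O)COc2cccc3ccccc23)CC1`. The change from compound 1 to compound 4 is naphthalen-1-yl in place of 4-hydroxyphenyl on an oxygen on a saturated carbon. Within the data shown here, the only measured step that bears directly on it is the one in which the same 4-hydroxyphenyl is exchanged for naphthalen-2-yl on the same oxygen, a 2.3-fold lower number from compound 1 to compound 3 (0.36 log units; beyond the scatter). Among the measured compounds shown here, the change to naphthalen-1-yl differs from that step only in the point at which the second six-membered aromatic ring is joined, and no measured pair shows what that alone does. The step from compound 2 to compound 3, a 2.9-fold lower number from compound 2 to compound 3 (0.45 log units; beyond the scatter), also points the same way for a naphthalene group on that position. Compound 4 is therefore expected to give a lower number than compound 1, by a step of about a 1.8-fold lower number from compound 1 to compound 4 (0.26 log units; within the scatter), of roughly the size seen for compound 3. The estimate for compound 4 in this assay is 2500 nM, within a range of 1000 nM to 6000 nM.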

Compound 4, inhibition constant: 2600 nM
Compound 4: the middle estimate sits 1.0-fold (0.02 log units) below what was measured, within the range that was stated.
By their numbers in this assay, from the lowest: compounds 3, 4, 1 and 2 (each within the scatter of the next, the first and the last beyond it).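

In this assay, moving the point of attachment on the oxygen, naphthalen-1-yl in place of naphthalen-2-yl, gives a step within the scatter (a 1.3-fold higher number from compound 3 to compound 4 (0.11 log units; within the scatter)), so the two naphthalene attachments cannot be told apart on this read-out. The exchange of 4-hydroxyphenyl for naphthalen-1-yl also stays within the scatter (a 1.8-fold lower number from compound 1 to compound 4 (0.25 log units; within the scatter)), whereas the exchange for naphthalen-2-yl lay just beyond it (a 2.3-fold lower number from compound 1 to compound 3 (0.36 log units; beyond the scatter)), so the separation from the 4-hydroxyphenyl ether is not secure for both naphthalene groups, and only the replacement of cyclohexylmethyl by (naphthalen-1-yl)oxy gives a step beyond the scatter (a 2.2-fold lower number from compound 2 to compound 4 (0.34 log units; beyond the scatter)). No evidence is available that explains any of these steps.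

The exchange of 4-hydroxyphenyl for a naphthalene group changes the ring count and removes the hydroxyl at once, so the compounds shown do not separate the two, and a plain phenyl ether would be the missing link. They also leave open what an amine or a carboxylic acid on the naphthalene, or a longer chain between the carbonyl and the oxygen, would do to the number.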